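From compound 1 to compound 4: a new ring

The source may hold more compounds than are shown below. What is called first, only, known or untested is meant among the compounds shown, and "the series" means these compounds.

In a physicochemical assay for solubility (a lower number here means a less soluble compound, a higher number a more soluble compound), compound 1 (`Cn1nccc1-c1cc(C(F)(F)F)ccc1[C@H]1CCOc2cc(S(=O)(=O)Nc3nccs3)ccc21`) gives 83000 nM and stands second highest of three numbers. Compound 2 (`Cn1nccc1-c1cc(C(F)(F)F)ccc1[C@H]1CCOc2cc(S(=O)(=O)Nc3ccc(F)cn3)ccc21`) gives 29000 nM and compound 3 (`Cn1nccc1-c1cc(C(F)(F)F)ccc1[C@H]1CCOc2cc(S(=O)(=O)Nc3cccnn3)ccc21`) gives 915000 nM in the same measurement. Compound 4 (`O=C1COCCN1c1cc(C(F)(F)F)ccc1[C@H]1CCOc2cc(S(=O)(=O)Nc3nccs3)ccc21`) has 3-oxomorpholin-4-yl in place of 1-methyl-1H-pyrazol-5-yl on an aromatic carbon. Among the compounds with values here, no measured step changes that place. All three change the group on a sulfonamide nitrogen, so they bear only indirectly. They show how far these numbers can move: modestly with a 2.9-fold lower number from compound 1 to compound 2 (0.46 log units; beyond the scatter) and greatly with an 11-fold higher number from compound 1 to compound 3 (1.04 log units; beyond the scatter) and with a 32-fold higher number from compound 2 to compound 3 (1.50 log units; beyond the scatter) in this series. The expected step is a 1.4-fold higher number from compound 1 to compound 4 (0.16 log units; within the scatter) and would stay within the scatter. For compound 4 the expected value is 120000 nM (estimated range 30000 nM to 450000 nM).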

Compound 4, solubility: 695000 nM
Beside the measured number, compound 4's estimate is 5.8-fold (0.76 log units) below it, and the stated range ends below it.
By their numbers in this assay, from the lowest: compound 2; then compound 1; then compounds 4 and 3 (each within the scatter of the next).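

In this assay, 3-oxomorpholin-4-yl in place of 1-methyl-1H-pyrazol-5-yl gives an 8.4-fold higher number from compound 1 to compound 4 (0.92 log units; beyond the scatter). Within the data shown here, the earlier steps all changed the group on the sulfonamide nitrogen, so this is the first sign that the aromatic carbon ortho to a large group can also move the number beyond the scatter.

On these data alone, it remains open whether a plain morpholine ring without the carbonyl, or an open-chain amide, would do the same here, and whether the step carries over to compound 2 and compound 3. No evidence here gives a cause for this step.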